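The compounds below may be only part of what the source reports. "The series", "measured", "known", "first", "only" and "open" are said of these compounds alone.

Measured in a functional assay on QGY-7703 cells (Homo sapiens) for cytotoxicity, read by MTT assay, with a stated time of 24 h; a higher number here means a weaker inhibitor, a lower number a stronger inhibitor:

- compound 1 `CC(=O)Nc1ccc(S(=O)(=O)N2C/C(=C\c3ccncc3)C(=O)/C(=C/c3ccccc3F)C2)cc1`: 13700 nM
- compound 2 `O=C1/C(=C/c2ccncc2)CN(S(=O)(=O)c2ccc(F)cc2)C/C1=C\c1ccccc1C(F)(F)F`: 7700 nM
- compound 3 `N#Cc1ccc(S(=O)(=O)N2C/C(=C\c3ccncc3)C(=O)/C(=C/c3ccccc3C(F)(F)F)C2)cc1`: 6290 nM

Compound 3 sits level with compound 2 within the scatter, while compound 1 lies beyond the scatter above compound 3. The next molecule, compound 4 `CC(=O)Nc1ccc(S(=O)(=O)N2C/C(=C\c3ccncc3)C(=O)/C(=C/c3ccccc3C(F)(F)F)C2)cc1`, changes one group of compound 3: acetamido in place of cyano on an aromatic carbon. Going by the values given here, one measured step concerns that same place: a 1.2-fold lower number from compound 2 to compound 3 (0.09 log units; within the scatter), a swap of cyano in place of fluoro that stayed within the scatter. Compound 4 differs elsewhere from compound 1, which also carries acetamido and gives 13700 nM. A small upward move is therefore expected, and the estimated step is a 1.4-fold higher number from compound 3 to compound 4 (0.16 log units; within the scatter). Compound 4 is expected at 9000 nM, within an estimated range of 4500 nM to 18000 nM.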

Compound 4, half-maximal inhibitory concentration: 5560 nM
Beside the measured number, compound 4's estimate is 1.6-fold (0.21 log units) above it; the measured number falls inside the stated range.
By their numbers in this assay, from the lowest: compounds 4, 3, 2 and 1 (each within the scatter of the next, the first and the last beyond it).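

Replacing the 4-cyanophenyl with 4-acetamidophenyl gives a 1.1-fold lower number from compound 3 to compound 4 (0.05 log units; within the scatter) and putting acetamido in place of fluoro gives a 1.4-fold lower number from compound 2 to compound 4 (0.14 log units; within the scatter), so this place tolerates the larger group with its hydrogen-bond donor without a measurable change. The clearer shift comes from the other aromatic ring, where trifluoromethyl in place of fluoro gives a 2.5-fold lower number from compound 1 to compound 4 (0.39 log units; beyond the scatter), though only as a modest step. No measurement shown explains either result.

From the compounds shown here alone, whether a free amine or a carboxylic acid at this place would also leave the number unmoved remains open. So does whether fluoro, cyano and acetamido would stay level with fluoro in place of trifluoromethyl on the other ring.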